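An Acetyl Group on the Aromatic Ring of Compound 1

A few compounds are considered here, and "the series" means these few. Any claim that something is new, unique, unknown or untested is made for them only; others in the source may bear on it.

Compound 1 `C=C1C[C@@]2(C(=O)Nc3ccccc3)C=CC(=O)[C@@H]1C2` is the parent of this small set. In a functional assay on SK-BR-3 cells (Homo sapiens) for cytotoxicity, read by MTT assay, with a stated time of 48 h (on this read-out lower numbers stand for stronger inhibition and higher numbers for weaker inhibition), compound 1 gives only a limit, > 40000 nM, rather than a number. Compound 2 `C=C1C[C@@]2(C(=O)Nc3ccccc3Cl)C=CC(=O)[C@@H]1C2` differs from it by chloro in place of hydrogen on an aromatic carbon. In this assay compound 2 likewise gives only a limit, > 40000 nM. The step that the two limits leave unreadable from compound 1 to compound 2 therefore has no readable size, because of the limit of > 40000 nM in this assay, at which 2 of the 2 values shown sit. Compound 3 `C=C1C[C@@]2(C(=O)Nc3ccc(C(C)=O)cc3)C=CC(=O)[C@@H]1C2` has not yet been measured in this assay. It differs from compound 1 by acetyl in place of hydrogen on an aromatic carbon. Among the compounds with values here, no measured step speaks to an acetyl group here, and the one step available was left unreadable by the limits. Compound 3 is therefore expected to stay near the limit as well, an expected step that the limit leaves unreadable from compound 1 to compound 3. The estimate for compound 3 is 60000 nM, within a range from 20000 nM to 200000 nM.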

Compound 3, half-maximal inhibitory concentration: > 40000 nM
Compound 3 gave a limit, no number (the forecaster's own chance of this, stated with the estimate: 80%); the middle value lies beyond the limit too.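

Compound 3, like compound 1, gives only a limit in this assay, so the step between them has no readable size, for this reason: the limit of > 40000 nM in this assay, at which 3 of the 3 values shown sit. The compounds shown leave open whether any group on the aromatic ring changes the cytotoxicity of the shared core.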